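This account rests on a few compounds, and the source may have more. Where it says the series, first, only, none or still open, it means among the compounds named here.

Three compounds share one core and differ only in an outer group attached at a carbonyl carbon. Among the compounds with values here, compound 1 `Cc1oc(=O)oc1COC(=O)c1cccc(NC(=O)[C@@H]2C[C@H](SC3=C(C(=O)O)N4C(=O)[C@H]([C@@H](C)O)[C@H]4[C@H]3C)CN2)c1` is the first of them. In an ADME assay for metabolic stability, read by LC-MS, with a stated time of 3 h, at pH 6.5, tested at 50 uM (on this read-out lower numbers stand for a less stable compound and higher numbers for a more stable compound), compound 1 gives a value that is a limit of the assay, > 95%. Compound 2 `C[C@@H](O)[C@H]1C(=O)N2C(C(=O)OCOC(=O)C3CCCCC3)=C(S[C@@H]3CN[C@H](C(=O)Nc4cccc(C(=O)O)c4)C3)[C@H](C)[C@H]12` is the second. In this assay compound 2 likewise reaches the limit, > 95%. Compound 3 `CC(C)OC(=O)OCOC(=O)C1=C(S[C@@H]2CN[C@H](C(=O)Nc3cccc(C(=O)O)c3)C2)[C@H](C)[C@@H]2[C@@H]([C@@H](C)O)C(=O)N12` is the third. In this assay compound 3 also stands at the limit, > 95%. The step that the two limits leave unreadable from compound 2 to compound 3 is therefore not readable in size or direction. Within the data shown here, the whole evidence amounts to the limit of > 95% in this assay, at which 3 of the 3 values shown sit: every measured compound sits at the same limit, so no step of any size has been resolved among them, and compound 3 stands where the others stand, at the top of what this assay can report.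

Compound 4 `CCC(CC)C(=O)OCOC(=O)C1=C(S[C@@H]2CN[C@H](C(=O)Nc3cccc(C(=O)O)c3)C2)[C@H](C)[C@@H]2[C@@H]([C@@H](C)O)C(=O)N12` differs from compound 3 by pentan-3-yl in place of isopropoxy on a carbonyl carbon. Among the measured compounds shown here, because all three measured values sit at the limit of > 95% in this assay, at which 3 of the 3 values shown sit, no measured step bears on this change, and the only expectation the data support is that compound 4 will again reach the limit. The step that the limit leaves unreadable from compound 3 to compound 4 is accordingly expected to be nothing beyond the scatter. Compound 4 is expected to give 96%, with a range from 85% to 100%, most likely reported once more only as a limit.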

Compound 4, percent of the compound remaining: > 95%
Compound 4 was reported as a limit (the forecaster's own chance of this, stated with the estimate: 80%); the middle value is on the limit's open side.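

In this assay compound 4 gives > 95%, which is a limit of the assay. Within the data shown here, no step from compound 2 or compound 3 to compound 4 can be read, in size or in direction: the limit of > 95% in this assay, at which 4 of the 4 values shown sit. The compounds shown leave open whether these outer groups differ at all on this read-out, as every value shown is the same limit.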